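This account rests on a few compounds, and the source may have more. Where it says the series, first, only, none or still open, it means among the compounds named here.

Measured compounds in a functional assay on HCT-116 cells (Homo sapiens) for inhibition, read by MTT assay, with a stated time of 2 days; a higher number here means a weaker inhibitor of growth, a lower number a stronger inhibitor of growth:
- compound 1 `COc1ccc(NC(=O)CNCCCC(=O)Nc2ccccc2N)cc1`: 8600 nM
- compound 2 `Nc1ccccc1NC(=O)c1ccc(NCC(=O)Nc2ccc(Cl)cc2)cc1`: 4200 nM

Going by the values given here, compound 1 stands highest of the two numbers in this assay; the only neighbour, compound 2, sits lower, and that gap lies beyond the scatter. Compound 3 `Nc1ccccc1NC(=O)CCCNCC(=O)Nc1cccc([N+](=O)[O-])c1` is not yet measured. It differs from compound 1 by 3-nitrophenyl in place of 4-methoxyphenyl on an amide-type nitrogen. No comparable change between measured compounds exists here, so its effect cannot be read from the series. A small step from compound 1 is expected, a 1.2-fold lower number from compound 1 to compound 3 (0.09 log units; within the scatter), likely not beyond the scatter. Compound 3 is estimated at 7000 nM, in the range 2500 nM to 20000 nM.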

Compound 3, concentration for 50% growth inhibition: 900 nM
Compound 3: the middle estimate sits 7.8-fold (0.89 log units) above what was measured, outside the stated range (below it).
By their numbers in this assay, from the lowest: compound 3; then compound 2; then compound 1.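

In this assay, the group on the amide-type nitrogen proves to be a sensitive point: 3-nitrophenyl in place of 4-methoxyphenyl gives a 9.6-fold lower number from compound 1 to compound 3 (0.98 log units; beyond the scatter) with the rest of the structure unchanged. The earlier compounds shown here, which differ in more than one place, could not isolate this position. No measurement at hand accounts for the step.

From the compounds shown here alone, whether the step follows the nitro group itself or its placing on the ring stays open; 4-nitrophenyl and 3-methoxyphenyl would separate the two. Going by these compounds, how unsubstituted phenyl or 3-aminophenyl would read at this nitrogen also remains open.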